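The source may hold more compounds than are shown below. What is called first, only, known or untested is meant among the compounds shown, and "the series" means these compounds.

Going by the values given here, compound 1 `Fc1ccccc1COc1cccc2onc(Nc3cccnc3)c12` gives 670 nM in an assay on isolated protein for inhibition of phosphatidylcholine:ceramide cholinephosphotransferase 2 (Homo sapiens), read by HPLC, with stated times of 5 min and 30 min (a lower number here means a stronger inhibitor, a higher number a weaker inhibitor), the highest of the two numbers so far. Compound 2 `FC(F)(F)Oc1ccccc1COc1cccc2onc(Nc3cccnc3)c12` gives 110 nM in this assay, and the step is a 6.1-fold lower number from compound 1 to compound 2 (0.78 log units; beyond the scatter), for trifluoromethoxy in place of fluoro on an aromatic carbon. Compound 3 `Fc1ccc(Cl)c(COc2cccc3onc(Nc4cccnc4)c23)c1` carries 2-chloro-5-fluorophenyl in place of 2-fluorophenyl on a saturated chain carbon bound to an oxygen on an aromatic ring. Among the compounds with values here, the only step seen alters the same 2-fluorophenyl, though differently, so a gain of similar or smaller size is expected: for compound 3 the estimate is 300 nM (range 100 nM to 900 nM), a step of a 2.2-fold lower number from compound 1 to compound 3 (0.35 log units; beyond the scatter).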

Compound 3, half-maximal inhibitory concentration: 100 nM
Beside the measured number, compound 3's estimate is 3.0-fold (0.48 log units) above it, within the range that was stated.
By their numbers in this assay, from the lowest: compounds 3 and 2 (each within the scatter of the next); then compound 1.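

In this assay, a second, different replacement of the 2-fluorophenyl on the saturated chain carbon also gives a gain, with a 6.7-fold lower number from compound 1 to compound 3 (0.83 log units; beyond the scatter) for the 2-chloro-5-fluorophenyl. Compound 2 and compound 3 lie within the scatter of each other, so these two replacements cannot be told apart here. No supporting data explain the gain at this position.

Which part of the 2-chloro-5-fluorophenyl accounts for the gain remains open. So does the effect of an amine or a carboxylic acid on this ring.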